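Swapping thiophen-2-yl for 4-chlorobenzyl on a shared core

This account rests on a few compounds, and the source may have more. Where it says the series, first, only, none or still open, it means among the compounds named here.

Values measured so far in a functional assay on HL-60 cells (Homo sapiens) for inhibition, read by CCK-8 assay, with a stated time of 48 h, tested at 20 uM (on this read-out lower numbers stand for less inhibition of growth and higher numbers for more inhibition of growth at the one concentration tested), are these
- compound 1 `COc1ccc(S(=O)(=O)Oc2ccccc2/C=C(\C#N)C(=O)Nc2nnc(-c3cccs3)s2)cc1` gives 67%
- compound 2 `N#C/C(=C\c1ccccc1OS(=O)(=O)c1ccc([N+](=O)[O-])cc1)C(=O)Nc1nnc(-c2cccs2)s1` gives 23%
- compound 3 `CC(=O)Nc1ccc(S(=O)(=O)Oc2cccc(/C=C(\C#N)C(=O)Nc3nnc(-c4cccs4)s3)c2)cc1` gives 71%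

Compound 1 lies within the scatter of compound 3, so these two cannot be ranked against each other, and it lies far from compound 2. The open question concerns compound 4 `COc1ccc(S(=O)(=O)Oc2ccccc2/C=C(\C#N)C(=O)Nc2nnc(Cc3ccc(Cl)cc3)s2)cc1`, which keeps the rest of compound 1 and exchanges one group (4-chlorobenzyl in place of thiophen-2-yl on an aromatic carbon) on an aromatic carbon of a five-membered aromatic ring with 2 nitrogen and 1 sulfur.

Within the data shown here, the one measured step (a number 44 percentage points lower from compound 1 to compound 2 (beyond the scatter)) is nitro in place of methoxy on an aromatic carbon. It shows that a single exchange can move this read-out a long way, but it involves different groups. All three measured compounds carry thiophen-2-yl, so nothing measured here tests the exchange directly. The best starting point is therefore compound 1 itself at 67%, with a small downward allowance and wide doubt in both directions. The expected change is only a rough estimate (a number 7 percentage points lower from compound 1 to compound 4 (within the scatter)). In this assay compound 4 is estimated at 60% (expected range 35% to 85%).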

Compound 4, percent growth inhibition at one concentration: 99%
The estimate for compound 4 lay 39 percentage points below the measured number; the whole stated range lies below it.
By their numbers in this assay, from the lowest: compound 2; then compounds 1 and 3 (each within the scatter of the next); then compound 4.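

In this assay, exchanging thiophen-2-yl for 4-chlorobenzyl gives a number 32 percentage points higher from compound 1 to compound 4 (beyond the scatter), so the group on this aromatic carbon of the five-membered ring can strongly change growth inhibition. Among these compounds, the earlier measured step involved nitro and methoxy at a different place, and all the earlier compounds carried thiophen-2-yl, so they could not show this. The new result also shows that this position tolerates a group with more heavy atoms and a six-membered carbon ring in place of the sulfur-containing ring, with compound 4 reaching 99%; nothing presented here explains why the change has such a large effect.

This one exchange alters the ring, adds chlorine and introduces a linking carbon, so the compounds shown cannot tell which of these changes matters, and plain benzyl or a directly attached phenyl would help separate them. As far as these compounds go, it also remains open whether 4-chlorobenzyl would raise the low value of compound 2, which carries nitro, and a single test concentration leaves little room to rank any group against compound 4.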